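Swapping two chlorines for two nitro groups on the amide ring

A few compounds are considered here, and "the series" means these few. Any claim that something is new, unique, unknown or untested is made for them only; others in the source may bear on it.

Two amides of a shared core have been measured in an assay on isolated protein for inhibition of protein-S-isoprenylcysteine O-methyltransferase (Homo sapiens); a lower number here means a stronger inhibitor, a higher number a weaker inhibitor. Compound 1 `CC(C)=CCC/C(C)=C/CC/C(C)=C/CSC[C@H](NC(=O)c1ccc([N+](=O)[O-])cc1)C(=O)O` gives 16600 nM in this assay, and compound 2 `CC(C)=CCC/C(C)=C/CC/C(C)=C/CSC[C@H](NC(=O)c1cc(Cl)cc(Cl)c1)C(=O)O` gives 23000 nM. On the numbers shown, compound 2 stands alongside compound 1, since the step of a 1.4-fold higher number from compound 1 to compound 2 (0.14 log units; within the scatter) lies within the scatter. Compound 3 `CC(C)=CCC/C(C)=C/CC/C(C)=C/CSC[C@H](NC(=O)c1cc([N+](=O)[O-])cc([N+](=O)[O-])c1)C(=O)O` differs from compound 2 in one place: 3,5-dinitrophenyl in place of 3,5-dichlorophenyl on a carbonyl carbon. Among the measured compounds shown here, the only measured step that bears on this change is the one from compound 1 to compound 2, where a nitro-bearing ring gave way to a chlorine-bearing ring without a shift beyond the scatter. Going back toward nitro groups, now two of them, is therefore expected to move this assay little, with no clear direction. For compound 3 the expected step of a 1.2-fold lower number from compound 2 to compound 3 (0.06 log units; within the scatter) is within the scatter. Compound 3 is estimated at 20000 nM, with a range from 8000 nM to 50000 nM.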

Compound 3, half-maximal inhibitory concentration: 14300 nM
Compound 3: middle estimate off by 1.4-fold (0.15 log units), on the high side; measured number inside the range.
By their numbers in this assay, from the lowest: compounds 3, 1 and 2 (each within the scatter of the next).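

In this assay, 3,5-dinitrophenyl in place of 3,5-dichlorophenyl on a carbonyl carbon gives a 1.6-fold lower number from compound 2 to compound 3 (0.21 log units; within the scatter) and so brings in a larger group with hydrogen-bond acceptors without a shift beyond the scatter. Set against the single nitro group of compound 1, the same ring gives a 1.2-fold lower number from compound 1 to compound 3 (0.06 log units; within the scatter) and so adds a second nitro group and moves its place on the ring, again within the scatter, leaving all three amides reading alike at this position. Nothing at hand explains why these three groups read alike.

The compounds leave open whether an amine on the ring, or a plain alkyl chain in place of the ring, would move the number in this assay beyond the scatter. They also leave open what a methyl ester would do in place of the free carboxylic acid of the shared core.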